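This account rests on a few compounds, and the source may have more. Where it says the series, first, only, none or still open, it means among the compounds named here.

Measured in an ADME assay on CCRF-HSB-2 cells (Homo sapiens) for cytotoxicity, with a stated time of 7 days; on this read-out higher numbers stand for lower toxicity in this test and lower numbers for higher toxicity in this test:
- Compound 1 `Nc1nc(NCc2ccccc2)c2ncn(/C=C3/CC3(CO)CO)c2n1`: > 20000 nM, a limit
- Compound 2 `Nc1nc(NC2CCCC2)c2ncn(/C=C3/CC3(CO)CO)c2n1`: > 20000 nM, a limit

Compound 2 therefore stands at a limit of the assay and has no numerical value. The same is true of compound 1, as the limit of > 20000 nM in this assay, at which 2 of the 2 values shown sit, shows. Compound 3 `CCCOc1nc(N)nc2c1ncn2/C=C1/CC1(CO)CO` carries propoxy in place of cyclopentylamino on an aromatic carbon. Within the data shown here, the only measured step is a step that the two limits leave unreadable from compound 1 to compound 2. Among the measured compounds shown here, it exchanges one group on the nitrogen for another and gives no size to carry over, and no measured step replaces that nitrogen. For the measured compounds named here, with the limit of > 20000 nM in this assay, at which 2 of the 2 values shown sit, as the sole guide, no shift beyond the scatter is expected in this assay, though a move towards higher toxicity cannot be excluded. The expected size is a step that the limit leaves unreadable from compound 2 to compound 3. For compound 3 the estimate is 22000 nM, with an expected range of 7000 nM to 60000 nM.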

Compound 3, half-maximal cytotoxic concentration: > 20000 nM
Compound 3: a limit, no number; the forecaster's own chance of this, stated with the estimate: 70%; the middle value is on the limit's open side.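

In this assay compound 3 gives > 20000 nM as a limit, so no step among compound 1, compound 2 and compound 3 can be read: the limit of > 20000 nM in this assay, at which 3 of the 3 values shown sit.

The compounds shown leave open whether benzylamino, cyclopentylamino and propoxy differ at all on this read-out, and at what concentration any of the three compounds becomes toxic to these cells.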